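A Longer Chain on a Compound at the Assay Limit

The source may hold more compounds than are shown below. What is called first, only, known or untested is meant among the compounds shown, and "the series" means these compounds.

Measured in an ADME assay on HCT-116 cells (Homo sapiens) for antiproliferative activity; a lower number here means a stronger inhibitor, a higher number a weaker inhibitor:
- compound 1 `COc1ccc(C(N)=O)cc1/C=C/c1ccc(Cl)cc1`: 7100 nM
- compound 2 `CCCOc1ccc(C(N)=O)cc1/C=C/c1ccc(Cl)cc1`: > 50000 nM (a limit)

In this assay compound 2 gives > 50000 nM, which is a limit of the assay and not a number. As far as these compounds go, the measurements so far include (the limit of > 50000 nM in this assay, at which 1 of the 2 values shown sits), so the true position of compound 2 is unknown.

Compound 3 `NC(=O)c1ccc(OCCOCCO)c(/C=C/c2ccc(Cl)cc2)c1` carries a further change to the chain: 2-hydroxyethoxy in place of methyl on a saturated chain carbon, two bonds along the chain from an oxygen on an aromatic ring. Its propoxy becomes 2-(2-hydroxyethoxy)ethoxy, on the same core.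

Within the data shown here, only one measured step bears on this change: an at least 7.0-fold higher number from compound 1 to compound 2 (0.84 log units; beyond the scatter). That step also extended the chain on the oxygen, and it made the number in this assay higher. Its size cannot simply be carried over, since it ends at a limit and the new group differs in kind from a plain alkyl extension.

No large recovery is therefore expected, and compound 3 may again be reported only as a limit. The expected change is small: an at least 1.4-fold lower number from compound 2 to compound 3 (0.15 log units; that floor lies within the scatter). For compound 3 the estimate is 35000 nM, with an expected range from 9000 nM to 120000 nM.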

Compound 3, half-maximal inhibitory concentration in the HCT-116 assay: 38000 nM
Compound 3: the middle estimate sits 1.1-fold (0.04 log units) below what was measured, within the range that was stated.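

In the HCT-116 assay compound 2 gives > 50000 nM, which is a limit of the assay and not a number. Among these compounds, compound 3 gives the first measured number for a chain longer than methoxy at this oxygen, and it still lies on the weaker side of compound 1, with a 5.4-fold higher number from compound 1 to compound 3 (0.73 log units; beyond the scatter), while the comparison with the propoxy compound gives only an at least 1.3-fold lower number from compound 2 to compound 3 (0.11 log units; that floor lies within the scatter), so no gain in the HCT-116 assay can be claimed for this change. The change does register clearly in a physicochemical assay for solubility, read by HPLC, in simulated intestinal fluid, with a stated time of 2 h, tested at 10 mM (a lower number here means a less soluble compound, a higher number a more soluble compound), where compound 2 gives 4 ug/mL and compound 3 gives 74 ug/mL: the measured solubility of compound 2, 4 ug/mL, and of compound 3, 74 ug/mL, a 19-fold higher number (1.27 log units; beyond the scatter)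

The compounds shown leave open whether the weaker number of compound 3 relative to compound 1 follows the length of the chain or what stands at its end, and a shorter 2-hydroxyethoxy chain, or the same chain ending in a methoxy group or an amine, would bear on that question. As far as these compounds go, it also remains open how compound 1 itself reads in the physicochemical assay, and so whether any chain at this oxygen can pair a number like that of compound 3 in that assay with the number of compound 1 in the HCT-116 assay.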